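A few compounds are considered here, and "the series" means these few. Any claim that something is new, unique, unknown or untested is made for them only; others in the source may bear on it.

Compound 1, `Oc1ccc(-c2cc(-c3ccccn3)cc(-c3ccccc3O)n2)cc1`, gives 0.2%. Compound 2, `Oc1cccc(-c2cc(-c3cccnc3)cc(-c3ccccc3O)n2)c1`, gives 1.9%.

In an assay on isolated protein for inhibition of DNA topoisomerase 1 (Homo sapiens), with a stated time of 30 min, tested at 100 uM (a higher number here means a stronger effect of the compound at the concentration tested, a lower number a weaker effect), compound 2 has the higher of the two numbers, but its gap to compound 1 lies within the scatter, so the two cannot be ordered. Compound 3, `Oc1ccc(-c2cc(-c3cccnc3)cc(-c3ccccc3O)n2)cc1`, has not yet been measured. It differs from compound 2 in one place: 4-hydroxyphenyl in place of 3-hydroxyphenyl on an aromatic carbon. Within the data shown here, no measured pair shows this change, and both measured compounds sit close to zero, so no step beyond the scatter is expected. For compound 3 the expected step is a number 0.4 percentage points lower from compound 2 to compound 3 (within the scatter). Compound 3 is estimated at 1.5%, within -3% to 8%.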

Compound 3, a percentage reported as inhibition, at one concentration (the size of the read-out at that concentration, not a potency): 1.5%
For compound 3 middle estimate and measured number coincide at the digits printed; the range from low to high includes it.
By their numbers in this assay, from the lowest: compounds 1, 3 and 2 (each within the scatter of the next).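

In this assay 4-hydroxyphenyl in place of 3-hydroxyphenyl, on the aromatic carbon next to the ring nitrogen, gives a number 0.4 percentage points lower from compound 2 to compound 3 (within the scatter) and pyridin-3-yl in place of pyridin-2-yl gives a number 1.3 percentage points higher from compound 1 to compound 3 (within the scatter) on the same core. Neither change in one place lifts the read-out away from close to zero, at this position or at the pyridine. No evidence bears on this result. The compounds shown leave open whether an amine or a carboxylic acid in place of the hydroxyl on this ring would give a read-out clearly above this level.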